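Removing a Methoxy From a Weakly Cytotoxic Indole Compound

The source may report more compounds than this note shows. Statements on the series, on what has been measured and on what is new or still open speak of the compounds shown alone.

Compound 1 `O=C(/C(=C\c1c(-c2ccccc2)[nH]c2ccccc12)C(=O)C(F)(F)F)c1ccco1`: 8100 nM
Compound 2 `COc1ccc(-c2[nH]c3ccc(OC)cc3c2/C=C(\C#N)S(=O)(=O)c2ccccc2)cc1`: > 100000 nM

Of the compounds shown here, two have so far been tested in an ADME assay on CRL-7065 cells (Homo sapiens) for cytotoxicity, read by MTT assay, with a stated time of 96 h; a lower number here means that less compound is needed, a higher number that more compound is needed for the effect. Compound 1 gives 8100 nM. Compound 2, by contrast, is known only as a limit of the assay, > 100000 nM, with no number of its own. Where it stands is therefore described by the limit of > 100000 nM in this assay, at which 1 of the 2 values shown sits, the edge of what the assay reports rather than a measured effect. Compound 3 `COc1ccc(-c2[nH]c3ccccc3c2/C=C(\C#N)S(=O)(=O)c2ccccc2)cc1` has not yet been measured; it differs from compound 2 in one place, (hydrogen in place of methoxy on an aromatic carbon). Among the compounds with values here, no step between measured compounds is available to guide the expectation, and the change is small in size. Compound 3 is therefore expected to show no step beyond the usual scatter, a number no higher from compound 2 to compound 3 (the limit leaves the size open). Compound 3 is expected at about 100000 nM, within the range 30000 nM to 300000 nM, and is likely to come back again only as a limit.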

Compound 3, half-maximal effective concentration: > 100000 nM
Compound 3: only a limit was reported (the forecaster's own chance of this, stated with the estimate: 70%); the middle value lies on the limit itself.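

No step can be read from compound 2 to compound 3, because both values are limits and not numbers: the limit of > 100000 nM in this assay, at which 2 of the 3 values shown sit.

The compounds shown leave open whether hydrogen in place of methoxy on an aromatic carbon changes the cytotoxicity of this pair at all.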